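Compound 3 to compound 4: a side-chain change

The compounds below may be only part of what the source reports. "The series", "measured", "known", "first", "only" and "open" are said of these compounds alone.

In a functional assay on the whole organism for inhibition, with Mus musculus as the target (on this read-out lower numbers stand for an effect already at smaller amounts and higher numbers for an effect only at larger amounts of compound), compound 1 `CN1Cc2c(N)cccc2C(c2ccc(F)cc2)C1` gives 0.25 mg/kg, and compound 2 `Cc1ccc(C2CN(C)Cc3c(N)cccc32)cc1` gives about about 1.2 mg/kg. Compound 3 `CCCNC(=O)Nc1cccc2c1CN(C)CC2c1ccccc1` reads > 80 mg/kg, which is a limit of the assay and not a number. It therefore stands at the limit of > 80 mg/kg in this assay, at which 1 of the 3 values shown sits, so no exact gap to the other two compounds can be stated.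

Compound 4 `CCNCCC(=O)Nc1cccc2c1CN(C)CC2c1ccccc1` has not yet been measured. It differs from compound 3 as follows: 2-(ethylamino)ethyl in place of propylamino on a carbonyl carbon. In short, 2-(ethylamino)ethyl stands in place of propylamino on a carbonyl carbon.

Within the data shown here, only one measured step is available: a 4.8-fold higher number from compound 1 to compound 2 (0.68 log units; beyond the scatter). This modest change, beyond the scatter, is methyl in place of fluoro on an aromatic carbon, not on a carbonyl carbon. It shows that a single substitution in this set can move the number, but it gives no direct measure for the present change. Among the measured compounds shown here, no measured compound carries 2-(ethylamino)ethyl, so the estimate remains loose, and compound 4 may also return only a limit.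

A modest move in this assay toward a lower number is expected, estimated as an at least 2.2-fold lower number from compound 3 to compound 4 (0.35 log units; beyond the scatter). For compound 4, the estimated value is 35 mg/kg, with an expected range of 8 mg/kg to 120 mg/kg.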

Compound 4, dose for half-maximal effect: > 160 mg/kg
Compound 4 ended at the assay's limit (the forecaster's own chance of this, stated with the estimate: 45%); middle value at least 4.5-fold (0.66 log units) away from the limit.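

In this assay, compound 3 reads > 80 mg/kg, which is a limit of the assay. Compound 4 reads > 160 mg/kg, also a limit of the assay. Among these compounds, no step from compound 3 to compound 4 can be read from these two limits. Going by these compounds, whether 2-(ethylamino)ethyl in place of propylamino on a carbonyl carbon moves the number at all, and how far, stays open.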